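Urea series on the shared core: compound 3 to compound 4

The source may report more compounds than this note shows. Statements on the series, on what has been measured and on what is new or still open speak of the compounds shown alone.

Measured so far:
- compound 1 `Cc1cccc(NC(=O)Nc2cc(Oc3ccc4nc(NC(=O)C5CC5)sc4c3)ccc2F)c1`: 93 nM
- compound 2 `CCOC(=O)c1cccc(NC(=O)Nc2cc(Oc3ccc4nc(NC(=O)C5CC5)sc4c3)ccc2F)c1`: 72 nM
- compound 3 `O=C(Nc1nc2ccc(Oc3ccc(F)c(NCc4cccc(C(F)(F)F)c4)c3)cc2s1)C1CC1`: "not determined" (no result reported)

In an assay for binding affinity to receptor-interacting serine/threonine-protein kinase 3 (Homo sapiens), read by KINOMEscan and polymerase chain reaction, with a stated time of 1 h (a higher number here means weaker binding, a lower number tighter binding), compound 1 gives 93 nM and compound 2 gives 72 nM. Among the measured compounds shown here, the only one-place step among the measured compounds is a 1.3-fold lower number from compound 1 to compound 2 (0.11 log units; within the scatter). For compound 3 the entry in this assay is "not determined" (no result reported), so compound 3 stands nowhere on the scale shown.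

Compound 4 `CC(=O)c1cccc(NC(=O)Nc2cc(Oc3ccc4nc(NC(=O)C5CC5)sc4c3)ccc2F)c1` differs from compound 3 by (3-acetylphenyl)carbamoyl in place of 3-(trifluoromethyl)benzyl on a nitrogen on an aromatic ring. This change puts compound 4 on the same framework as compound 1 and compound 2, where the group on the outer aromatic ring is now an acetyl rather than a methyl or an ethoxycarbonyl. For the measured compounds named here, no measured step bears directly on the change from compound 3 to compound 4, since compound 3 has no value. What does bear on compound 4 is the pair compound 1 and compound 2: the step of a 1.3-fold lower number from compound 1 to compound 2 (0.11 log units; within the scatter) shows that exchanging the group on that ring left this assay within its scatter. Compound 4 is therefore expected to fall in the same region as compound 1 and compound 2, with no step beyond the scatter in either direction. The estimate for compound 4 in this assay is 80 nM, with a range of 35 nM to 180 nM.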

Compound 4, dissociation constant: 53 nM
Beside the measured number, compound 4's estimate is 1.5-fold (0.18 log units) above it; the measured number falls inside the stated range.
By their numbers in this assay, from the lowest: compounds 4, 2 and 1 (each within the scatter of the next).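

In this assay, acetyl joins methyl and ethoxycarbonyl as a third group on this aromatic carbon of the urea series, and both new comparisons stay within the scatter: a 1.8-fold lower number from compound 1 to compound 4 (0.24 log units; within the scatter) and a 1.4-fold lower number from compound 2 to compound 4 (0.13 log units; within the scatter). The earlier pair gave one step at this position, whereas the three compounds now give three steps, none of them beyond the scatter, so this assay does not separate methyl, acetyl and ethoxycarbonyl at this position, and methyl in place of ethoxy on the carbonyl carbon likewise gives no separation. The change from 3-(trifluoromethyl)benzyl to (3-acetylphenyl)carbamoyl on the nitrogen cannot be read, as compound 3 has no number, and no supporting measurement bears on these results.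

The compounds shown leave open whether a carboxylic acid, an amine or a longer chain on this aromatic carbon would stay within the same scatter or produce the first step beyond it. They also leave open how much the urea itself contributes in this assay, as the only compound shown without it has no number.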